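This account rests on a few compounds, and the source may have more. Where it says the series, first, only, none or still open, it means among the compounds named here.

Of the compounds shown here, three sharing one core have been tested in a functional assay on MKN-45 cells (Homo sapiens) for cytotoxicity, read by MTT assay, with a stated time of 72 h; a lower number here means a stronger inhibitor, a higher number a weaker inhibitor. Compound 1 `CN(C)CCn1cnnc1-c1cc(Oc2ccc(NC(=O)N/N=C/c3cccc(Cl)c3Cl)cc2F)ccn1` gives 51 nM. Compound 2 `CN(C)CCn1cnnc1-c1cc(Oc2ccc(NC(=O)N/N=C/c3ccc(O)cc3)cc2F)ccn1` gives 820 nM, and compound 3 `CN(C)CCn1cnnc1-c1cc(Oc2ccc(NC(=O)N/N=C/c3ccc(F)cc3)cc2F)ccn1` gives 1030 nM, the highest number of the three, although its gap to compound 2, a 1.3-fold higher number from compound 2 to compound 3 (0.10 log units; within the scatter), lies within the scatter, whereas a 20-fold higher number from compound 1 to compound 3 (1.31 log units; beyond the scatter) lies well beyond it. Compound 4 `COc1cc(/C=N/NC(=O)Nc2ccc(Oc3ccnc(-c4nncn4CCN(C)C)c3)c(F)c2)ccc1O` differs from compound 3 by 4-hydroxy-3-methoxyphenyl in place of 4-fluorophenyl on a carbon with a double bond to nitrogen. The step that bears most on this is a 1.3-fold higher number from compound 2 to compound 3 (0.10 log units; within the scatter), where a hydroxy and a fluoro on the same ring gave numbers within the scatter of each other; a 16-fold higher number from compound 1 to compound 2 (1.21 log units; beyond the scatter) and a 20-fold higher number from compound 1 to compound 3 (1.31 log units; beyond the scatter) show that only the 2,3-dichlorophenyl stands apart. No change beyond the scatter is therefore expected in this assay, a 1.3-fold lower number from compound 3 to compound 4 (0.11 log units; within the scatter). Compound 4 is estimated at 800 nM, between 300 nM and 2500 nM.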

Compound 4, half-maximal inhibitory concentration: 3780 nM
Beside the measured number, compound 4's estimate is 4.7-fold (0.67 log units) below it; the whole stated range lies below it.
By their numbers in this assay, from the lowest: compound 1; then compounds 2 and 3 (each within the scatter of the next); then compound 4.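

Compounds 2 and 3 gave no sign that this position could separate one single-ring group from another, but the added methoxy on the 4-hydroxyphenyl ring does so (a 4.6-fold higher number from compound 2 to compound 4 (0.66 log units; beyond the scatter)). The 4-hydroxy-3-methoxyphenyl group also trails the 4-fluorophenyl group (a 3.7-fold higher number from compound 3 to compound 4 (0.56 log units; beyond the scatter)) and lies far from the 2,3-dichlorophenyl group (a 74-fold higher number from compound 1 to compound 4 (1.87 log units; beyond the scatter)). Nothing available explains this loss. Still open is whether the loss is tied to methoxy itself, since the compounds shown leave open how an ethoxy chain or an amine would behave on this ring.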